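A few compounds are considered here, and "the series" means these few. Any claim that something is new, unique, unknown or untested is made for them only; others in the source may bear on it.

Three compounds share one core: compound 1, `CC(C)N(Cc1cccc(OCCCCCC(=O)O)c1)C(=O)c1ccc(-c2ccncc2)cc1`, compound 2, `CC(C)N(Cc1cccc(OCCCCCC(=O)O)c1)C(=O)c1ccc(-c2cccc(F)c2)cc1`, and compound 3, `CCOC(=O)CCCCCOc1cccc(CN(C(=O)c2ccc(-c3ccncc3)cc2)C(C)C)c1`. In an ADME assay on HEK293 cells (Homo sapiens) for cytotoxicity, read by CellTiter-Glo and resazurin assay, with a stated time of 72 h (a lower number here means that less compound is needed, a higher number that more compound is needed for the effect), compound 1 reaches only the limit > 26000 nM, a limit of the assay and not a number. Compound 2 likewise gives only the limit > 26000 nM. Compound 3 too stands at the limit > 26000 nM. The two measured steps, a step that the two limits leave unreadable from compound 1 to compound 2 and a step that the two limits leave unreadable from compound 1 to compound 3, are unreadable in size because of the limit of > 26000 nM in this assay, at which 3 of the 3 values shown sit. The unmeasured compound 4, `CCOC(=O)CCCCCOc1cccc(CN(C(=O)c2ccc(-c3cccc(OCC)c3)cc2)C(C)C)c1`, differs from compound 3 by 3-ethoxyphenyl in place of pyridin-4-yl on an aromatic carbon. Among the compounds with values here, no measured step offers a readable size for this change, so compound 4 is expected to stay at the limit as well, an expected step that the limit leaves unreadable from compound 3 to compound 4. Compound 4 is estimated at 40000 nM, within a range from 20000 nM to 100000 nM.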

Compound 4, half-maximal effective concentration: > 22300 nM
Compound 4: only a limit was reported (the forecaster's own chance of this, stated with the estimate: 85%); the middle value lies beyond the limit too.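

Compound 3 and compound 4 both give limits and not numbers in this assay, and the step between them cannot be read. The compounds shown leave open at what concentration any of them reaches the half-maximal effect.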